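One Aryl Exchange on the Ring Nitrogen of Compound 3

This account rests on a few compounds, and the source may have more. Where it says the series, first, only, none or still open, it means among the compounds named here.

Compound 1 `CCc1cccc(NC(=O)CSc2nc(Nc3ccccc3)c3ccccc3n2)c1` gives 12400 nM
Compound 2 `O=C(CSc1nc(Nc2ccccc2)c2ccccc2n1)Nc1ccc(Cl)c(Cl)c1` gives 14500 nM
Compound 3 `C=CC(=O)Nc1cccc(NC(=O)CSc2nc(Nc3ccccc3Br)c3ccccc3n2)c1` gives 15200 nM

All three were run in a functional assay on MDA-MB-231 cells (Homo sapiens) for inhibition, read by MTT assay, with a stated time of 72 h; on this read-out lower numbers stand for stronger inhibition and higher numbers for weaker inhibition. Compound 3 carries the highest of the three numbers, but its gaps to compound 2 and to compound 1 lie within the scatter, so nothing separates them. Among the measured compounds shown here, the sole step between measured compounds, a 1.2-fold higher number from compound 1 to compound 2 (0.07 log units; within the scatter), exchanges the aryl on the amide-type nitrogen. Compound 4 `C=CC(=O)Nc1cccc(NC(=O)CSc2nc(Nc3ccc(F)cc3)c3ccccc3n2)c1` differs from compound 3 by 4-fluorophenyl in place of 2-bromophenyl on a nitrogen on an aromatic ring. For the measured compounds named here, no measured step touches that nitrogen; the one known step bears on it only loosely, as a sign that aryl exchanges here have moved the read-out little. Compound 4 is therefore expected close to compound 3, with a 1.0-fold lower number from compound 3 to compound 4 (0.01 log units; within the scatter) expected to stay within the scatter. Compound 4 is estimated at 15000 nM, between 6000 nM and 38000 nM.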

Compound 4, half-maximal inhibitory concentration: 9490 nM
Compound 4: the middle estimate sits 1.6-fold (0.20 log units) above what was measured; low and high end bracket the measured number.
By their numbers in this assay, from the lowest: compounds 4, 1, 2 and 3 (each within the scatter of the next).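

At the nitrogen on an aromatic ring, 4-fluorophenyl in place of 2-bromophenyl gives, in this assay, a 1.6-fold lower number from compound 3 to compound 4 (0.20 log units; within the scatter), so this first measured exchange at that position stays within the scatter. The halogen and its place on the aryl ring change together, so this single step cannot separate the two. No supporting evidence bears on this result. The compounds shown leave open whether an aryl ring carrying an amine or a carboxylic acid on that nitrogen, or a longer alkyl chain in place of the aryl ring, would move the number beyond the scatter.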